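A few compounds are considered here, and "the series" means these few. Any claim that something is new, unique, unknown or untested is made for them only; others in the source may bear on it.

Measured so far:
- compound 1, `N[C@H](C(=O)O)C(Cc1ccccc1)C(=O)O`: in an in vitro assay on cells for inhibition of excitatory amino acid transporter 3 (Homo sapiens), tested at 100 uM (a lower number here means less inhibition, a higher number more inhibition at the concentration tested (going by the name of the read-out)), compound 1 gives 4%
- compound 2, `Cc1cccc(CC(C(=O)O)[C@H](N)C(=O)O)c1`: in this assay compound 2 gives 33%

Compound 2 stands highest of the two numbers in this assay; the nearest is compound 1, and the step of a number 29 percentage points higher from compound 1 to compound 2 (beyond the scatter) is beyond the scatter, a modest rise that goes with methyl in place of hydrogen on an aromatic carbon.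

Compound 3, `N[C@H](C(=O)O)C(Cc1cccc(Br)c1)C(=O)O`, is not yet measured. It differs from compound 2 in one place: bromo in place of methyl on an aromatic carbon. Among the compounds with values here, the single measured step, a number 29 percentage points higher from compound 1 to compound 2 (beyond the scatter), touches the same aromatic carbon but swaps hydrogen for methyl, not methyl for bromo, so it bears on the new step only loosely. Within the data shown here, there is no measured pair with a bromo group, and nothing in the two numbers indicates which way the exchange of methyl for bromo would move the read-out. The expectation is therefore a step of a number 2 percentage points higher from compound 2 to compound 3 (within the scatter) that stays within the scatter, with no clear direction.

On that basis compound 3 is estimated at 35% in this assay, with a range from 10% to 60%.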

Compound 3, a percentage reported as inhibition, at one concentration (the size of the read-out at that concentration, not a potency): 8%
Estimate against measurement, compound 3: 27 percentage points above, and the stated range ends above it.
By their numbers in this assay, from the lowest: compounds 1 and 3 (each within the scatter of the next); then compound 2.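

In this assay, this aromatic carbon, meta to a large group, does not treat its one-atom substituents alike: the exchange of methyl for bromo gives a number 25 percentage points lower from compound 2 to compound 3 (beyond the scatter), although each group counts 1 heavy atom and 0 hydrogen-bond donors or acceptors. So the rise seen with methyl does not carry over to every group of this size at this place, and bromo in place of hydrogen gives a number 4 percentage points higher from compound 1 to compound 3 (within the scatter), which leaves methyl as the only one of the three groups shown that stands apart from the others. No measurement on hand bears on why methyl and bromo part here.

Open, as far as these compounds go, is whether chloro, methoxy or a longer chain such as ethyl at the same aromatic carbon would follow methyl or bromo, and so whether methyl is a lone case or one of a wider set of groups. Also open, from the compounds shown here alone, is whether methyl would give a similar rise on another carbon of the ring, and how these read-outs at one concentration relate to potency.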